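Notes on a decyl and perfluoroalkyl triazolylquinoline cytotoxicity series

The compounds below may be only part of what the source reports. "The series", "measured", "known", "first", "only" and "open" are said of these compounds alone.

Measured so far in a functional assay on U-937 cells (Homo sapiens) for cytotoxicity, read by MTT assay, with a stated time of 24 h; a higher number here means a weaker inhibitor, a lower number a stronger inhibitor:
compound 1, `CCCCCCCCCCn1cc(-c2nc3ccccc3cc2CCCC)nn1`, 25.2 ug/mL
compound 2, `CCCCCCCCCCn1cc(-c2nc3ccccc3cc2CCC)nn1`, 26.6 ug/mL
compound 3, `CCCc1cc2ccccc2nc1-c1cn(CCC(F)(F)C(F)(F)C(F)(F)C(F)(F)C(F)(F)C(F)(F)C(F)(F)C(F)(F)F)nn1`, a limit only, > 100 ug/mL

Compound 1 and compound 2 differ by methyl in place of hydrogen on a saturated chain carbon, three bonds along the chain from an aromatic carbon. The resulting step is a 1.1-fold lower number from compound 2 to compound 1 (0.02 log units; within the scatter). For compound 3 the reading is a limit of this assay, > 100 ug/mL, as noted in the limit of > 100 ug/mL in this assay, at which 1 of the 3 values shown sits. The difference between the core of compound 3 and the core of compound 2 is not broken down here.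

Compound 4, `CCCCc1cc2ccccc2nc1-c1cn(CCC(F)(F)C(F)(F)C(F)(F)C(F)(F)C(F)(F)C(F)(F)C(F)(F)C(F)(F)F)nn1`, is still to be measured in this assay. It differs from compound 3 by methyl in place of hydrogen on a saturated chain carbon, three bonds along the chain from an aromatic carbon, the same change as that between compound 2 and compound 1. Because that earlier step, a 1.1-fold lower number from compound 2 to compound 1 (0.02 log units; within the scatter), lies within the scatter, no shift is expected here either. The expected step is a step that the limit leaves unreadable from compound 3 to compound 4, resting on a 1.1-fold lower number from compound 2 to compound 1 (0.02 log units; within the scatter). Compound 4 is therefore expected to return another limit, with an estimate of 150 ug/mL and a range from 60 ug/mL to 400 ug/mL.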

Compound 4, half-maximal inhibitory concentration: 59.1 ug/mL
For compound 4 the middle estimate is 2.5-fold (0.40 log units) above the measured one; measured number outside the range, below it.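

In this assay, going from propyl to butyl on the core with the fluorinated chain gives an at least 1.6-fold lower number from compound 3 to compound 4 (0.22 log units; that floor lies within the scatter) and leaves compound 4 with a measured number. Compound 3 remains a limit of the assay, so only a floor is known for this step, and its true size stays unread. Set beside the same change on the decyl core, the comparison reads: the same change on two cores in this assay, a 1.1-fold lower number (0.02 log units; within the scatter) from compound 2 to compound 1 and an at least 1.6-fold lower number (0.22 log units; that floor lies within the scatter) from compound 3 to compound 4; the limit leaves it open whether they differ

These two pairs therefore do not show that the change carries over unchanged from one core to the other, nor do they show that it behaves differently on the two cores.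

The compounds shown hold only propyl and butyl at this place, and only decyl and one fluorinated chain on the triazole nitrogen side of the structure. As far as these compounds go, whether a pentyl or hexyl chain, or an amine or a carboxylic acid in place of the butyl chain, would move the number on either core stays open.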